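Aniline replacement on the shared core: compound 4

The source may hold more compounds than are shown below. What is called first, only, known or untested is meant among the compounds shown, and "the series" means these compounds.

Measured so far in a functional assay on SMMC-7721 cells (Homo sapiens) for inhibition, read by MTT assay, with a stated time of 48 h; on this read-out lower numbers stand for stronger inhibition and higher numbers for weaker inhibition:
compound 1 `Cc1c[nH]c2nc(Nc3ccc4c(c3)CC(=O)N4)nc(NCc3cccnc3N(C)S(C)(=O)=O)c12` gives 18700 nM.
compound 2 `CN(c1ncccc1CNc1nc(Nc2ccc3c(c2)CC(=O)N3)nc2[nH]cc(C#N)c12)S(C)(=O)=O` gives only a limit of the assay, > 100000 nM.
compound 3 `CN(c1ncccc1CNc1nc(Nc2ccc(F)cc2)nc2[nH]cc(F)c12)S(C)(=O)=O` gives 27900 nM.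

Among the two numbers, compound 3 stands highest, yet its nearest neighbour compound 1 sits within the scatter of it, so no order between the two is claimed. Going by the values given here, the one step measured so far, an at least 5.3-fold higher number from compound 1 to compound 2 (0.72 log units; beyond the scatter), concerns the pyrrole carbon substituent and touches the limit noted as the limit of > 100000 nM in this assay, at which 1 of the 3 values shown sits.

Compound 4 `CC(=O)NCc1cccc(Nc2nc(NCc3cccnc3N(C)S(C)(=O)=O)c3c(F)c[nH]c3n2)c1` differs from compound 3 only by 3-(acetamidomethyl)phenyl in place of 4-fluorophenyl on a nitrogen on an aromatic ring. Among the compounds with values here, no measured step bears on this position, so no shift beyond the scatter is expected in this assay; the expected step is a 1.0-fold higher number from compound 3 to compound 4 (0.00 log units; within the scatter). Compound 4 is estimated at 28000 nM, within 8000 nM to 100000 nM.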

Compound 4, half-maximal inhibitory concentration: 21700 nM
Compound 4: middle estimate off by 1.3-fold (0.11 log units), on the high side; the range from low to high includes it.
By their numbers in this assay, from the lowest: compounds 1, 4 and 3 (each within the scatter of the next). At a limit, above all of these: compound 2.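

Replacing 4-fluorophenyl with 3-(acetamidomethyl)phenyl on a nitrogen on an aromatic ring gives a 1.3-fold lower number from compound 3 to compound 4 (0.11 log units; within the scatter) in this assay. Going by these compounds alone, this is the first reading at this position, and it shows that the exchange, which brings in an amide with a hydrogen-bond donor and acceptor, produces no shift that can be read in this assay. Nothing among the data shown accounts for this result.

Open, from the compounds shown here alone, is whether a carboxylic acid or an amine in place of the acetamidomethyl group would leave the number equally unmoved. Also open, going by these compounds, is whether a longer chain carrying the same amide would do so.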